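Removing a Terminal Vinyl Group: Effect on Cytotoxicity

A few compounds are considered here, and "the series" means these few. Any claim that something is new, unique, unknown or untested is made for them only; others in the source may bear on it.

Compound 1, `C=CCCCCCCCC#CC#CC(O)CC(C)=O`, in a functional assay on SK-MEL-2 cells (Homo sapiens) for cytotoxicity; on this read-out higher numbers stand for an effect only at larger amounts of compound and lower numbers for an effect already at smaller amounts: 3.52 ug/mL
Compound 2, `CCCCCCCC#CC#CC(O)CC(C)=O`, in this assay: 1.4 ug/mL
Compound 3, `C=CCCCCCCCC#CC#CCOCC(=O)OC`, in this assay: > 30 ug/mL (a limit of the assay, not a number)

Compound 1 and compound 2 differ by hydrogen in place of vinyl on a saturated chain carbon, seven bonds along the chain from a triple-bonded carbon, and this change gave a 2.5-fold lower number from compound 1 to compound 2 (0.40 log units; beyond the scatter). Compound 3 differs from compound 1 in more than one place, and the difference between the two cores is not broken down here. For compound 3 only a limit is known, namely (the limit of > 30 ug/mL in this assay, at which 1 of the 3 values shown sits). Compound 4, `CCCCCCCC#CC#CCOCC(=O)OC`, is not yet measured; it relates to compound 3 by the same change, (hydrogen in place of vinyl on a saturated chain carbon, seven bonds along the chain from a triple-bonded carbon). By analogy with the earlier step, compound 4 is expected to show a number no higher from compound 3 to compound 4 (the limit leaves the size open), though this rests on a single measured step and on a starting point that is only a limit. Compound 4 is therefore estimated at 30 ug/mL, between 10 ug/mL and 100 ug/mL.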

Compound 4, concentration for half-maximal effect: > 30 ug/mL
Compound 4: no number, only a limit; the forecaster's own chance of this, stated with the estimate: 60%; the middle value lies on the limit itself.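

Among these compounds, compound 3 and compound 4 both stand only as limits of the assay, so no step between them can be read: the limit of > 30 ug/mL in this assay, at which 2 of the 4 values shown sit. Going by these compounds, whether hydrogen in place of vinyl changes the number on the core of compound 3, as it does on the core of compound 1, remains open.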